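The source may hold more compounds than are shown below. What is called first, only, known or untested is meant among the compounds shown, and "the series" means these compounds.

Three compounds built on a shared core have been characterised in an assay on HEK293 cells for displacement of a labelled ligand from 5-hydroxytryptamine receptor 7 (Homo sapiens); on this read-out lower numbers stand for stronger inhibition and higher numbers for weaker inhibition. Compound 1 `O=C1c2ccccc2S(=O)(=O)N1CCCCCN1CCN(c2ccc(Cl)cc2)CC1` gives 191 nM in this assay. Compound 2 `O=C1c2ccccc2S(=O)(=O)N1CCCCCCN1CCN(c2cccc(Cl)c2Cl)CC1` gives 487 nM in this assay, and compound 3 `COc1ccccc1N1CCN(Cc2ccc(CN3C(=O)c4ccccc4S3(=O)=O)cc2)CC1` gives 97 nM in this assay. Among these three numbers compound 1 stands second highest. Compound 3 lies nearest to it, with a gap that sits within the usual scatter, while compound 2 lies furthest, with a gap that goes beyond it.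

Compound 4 `O=C1c2ccccc2S(=O)(=O)N1CCCCCN1CCN(c2ccccc2)CC1` has not yet been measured in this assay. It differs from compound 1 in one place: hydrogen in place of chloro on an aromatic carbon. Going by the values given here, no pair of measured compounds differs in exactly this way, so the size of the step has to be judged from the change alone. Compound 4 is expected to give a number close to that of compound 1 in this assay, shifted slightly toward weaker inhibition but probably not beyond the scatter. The expected step is a 1.5-fold higher number from compound 1 to compound 4 (0.17 log units; within the scatter). The estimate for compound 4 in this assay is 280 nM, within a range from 100 nM to 800 nM.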

Compound 4, inhibition constant: 148 nM
Beside the measured number, compound 4's estimate is 1.9-fold (0.28 log units) above it, and the stated range covers the measured number.
By their numbers in this assay, from the lowest: compounds 3, 4 and 1 (each within the scatter of the next); then compound 2.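

Going from 4-chlorophenyl to phenyl, on an aromatic carbon para to a large group, is a 1.3-fold lower number from compound 1 to compound 4 (0.11 log units; within the scatter) in this assay, so this read-out does not separate the two compounds and the chloro group can leave this place without a step beyond the scatter. Going by these compounds alone, none of the earlier compounds differed from one another in only one place, so this pair alone isolates the position and this change. No supporting data bear on this result.

From the compounds shown here alone, whether this place tolerates other groups as well, such as a carboxylic acid, an amine or a methoxy group, remains open, as a single replacement by hydrogen does not settle it. Going by these compounds, it also remains open whether the same change would read alike with a longer chain on the shared core.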